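A few compounds are considered here, and "the series" means these few. Any claim that something is new, unique, unknown or untested is made for them only; others in the source may bear on it.

Measured compounds:
- compound 2 `CCc1ccc(C(=O)NCCCN2CCN(CCCNc3ccnc4cc(Cl)ccc34)CC2)cc1`: 3900 nM
- compound 3 `O=C(NCCCN1CCN(CCCNc2ccnc3cc(Cl)ccc23)CC1)c1ccc(F)c(F)c1`: 10000 nM

Compound 1 `CCCCCC(=O)NCCCN1CCN(CCCNc2ccnc3cc(Cl)ccc23)CC1` has no result in an ADME assay on L6 cells (Rattus norvegicus) for cytotoxicity; a higher number here means a weaker inhibitor, a lower number a stronger inhibitor: its entry reads "not determined" (no result reported), and it stands nowhere on the numbers shown. Compound 4 `O=C(CCCOc1ccccc1)NCCCN1CCN(CCCNc2ccnc3cc(Cl)ccc23)CC1` differs from compound 1 by phenoxy in place of ethyl on a saturated chain carbon, three bonds along the chain from a carbonyl carbon. Among the measured compounds shown here, the one measured step, a 2.6-fold higher number from compound 2 to compound 3 (0.41 log units; beyond the scatter), changes the aryl group on the carbonyl carbon and does not bear on a change along the saturated chain. With compound 1 unmeasured, only the values of compound 2 and compound 3 set the scale, both in the micromolar range and separated by a modest step. Compound 4 is therefore expected to fall near them, with a direction that cannot be told, and its estimate in this assay is 6000 nM, between 2000 nM and 20000 nM.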

Compound 4, half-maximal inhibitory concentration: 9300 nM
Compound 4: middle estimate off by 1.6-fold (0.19 log units), on the low side; the range from low to high includes it.
By their numbers in this assay, from the lowest: compound 2; then compounds 4 and 3 (each within the scatter of the next).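

In this assay, a saturated chain ending in phenoxy on the carbonyl carbon reads the same as an aryl group directly there, with a 1.1-fold lower number from compound 3 to compound 4 (0.03 log units; within the scatter). The 3-phenoxypropyl group also stands apart from 4-ethylphenyl, with a 2.4-fold higher number from compound 2 to compound 4 (0.38 log units; beyond the scatter), as 3,4-difluorophenyl does. Nothing available here explains either step. The step from compound 1, pentyl to 3-phenoxypropyl, cannot be read. Going by these compounds, it remains open how an amine or a carboxylic acid in place of phenoxy, or a longer chain before it, would read.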